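Swapping neopentylamino for isobutoxy with no starting number

The source may hold more compounds than are shown below. What is called first, only, known or untested is meant among the compounds shown, and "the series" means these compounds.

Measured so far in a physicochemical assay for solubility; on this read-out higher numbers stand for higher solubility and lower numbers for lower solubility
Compound 1 (`C[C@@H]1CN(c2cc(C(F)(F)F)nn2-c2ccc(S(C)(=O)=O)cn2)[C@H](C)CO1`) gives 100 ug/mL
Compound 2 (`CS(=O)(=O)c1ccc(-n2nc(C(F)(F)F)cc2NC2CCCC2)nc1`) gives 25 ug/mL
Compound 3 (`CC(C)(C)CNc1cc(C(F)(F)F)nn1-c1ccc(S(C)(=O)=O)cn1`) gives "not determined" (no result reported)

Compound 3 has no number in this assay to stand on, so it cannot serve as a starting point. The change from it is isobutoxy in place of neopentylamino on an aromatic carbon and this gives compound 4 (`CC(C)COc1cc(C(F)(F)F)nn1-c1ccc(S(C)(=O)=O)cn1`), with isobutoxy in place of neopentylamino on an aromatic carbon.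

Among the measured compounds shown here, only one measured step offers any guidance. That step is a 4.0-fold lower number from compound 1 to compound 2 (0.60 log units; beyond the scatter) and it too exchanges one group for another on an aromatic carbon. It is a modest step, but it involves neither of the groups in the present swap, so it can only hint at how far such an exchange may move the number. With no value for compound 3, no size or direction can be expected for the step to compound 4.

The estimate must therefore rest on the measured neighbours. Isobutoxy is closer in size to the group on compound 2 than to the one on compound 1, so compound 2 (25 ug/mL) is the better anchor. Compound 4 is expected at about 22 ug/mL with an estimated range from 6 ug/mL to 80 ug/mL on this measurement.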

Compound 4, solubility: 50 ug/mL
Compound 4: the middle estimate sits 2.3-fold (0.36 log units) below what was measured, and the stated range covers the measured number.
By their numbers in this assay, from the lowest: compounds 2, 4 and 1 (each within the scatter of the next, the first and the last beyond it).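

The step reads as a 2.0-fold higher number from compound 2 to compound 4 (0.30 log units; within the scatter) and as a 2.0-fold lower number from compound 1 to compound 4 (0.30 log units; within the scatter) in this assay on this aromatic carbon of the shared core. Isobutoxy, a group with no ring, therefore gives a readable number at a position that until now had readable numbers only for groups with a ring, and compound 4 cannot be told apart from either compound 1 or compound 2, even though those two lie beyond the scatter of each other. These steps show how far the number moved but not why, and no separate measurement on these compounds bears on the cause.

On these data alone, compound 3 has no number, so the direct step from neopentylamino to isobutoxy cannot be read, and the effect of exchanging the nitrogen link for an oxygen link on two closely matched open chains remains unknown. The compounds shown also leave open where the number would fall with a carboxylic acid, a primary amine or a longer chain on this same aromatic carbon, groups that would test this position well beyond the small set of groups seen so far.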